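This account rests on a few compounds, and the source may have more. Where it says the series, first, only, none or still open, it means among the compounds named here.

Measured compounds:
compound 1 `O=C(Nc1ccc2c(c1)B(O)OC2)c1c(F)cccc1C(F)(F)F`, in a functional assay on PBMC cells (Homo sapiens) for inhibition, read by HTRF, with stated times of 15 min and 24 h (a higher number here means a weaker inhibitor, a lower number a stronger inhibitor), compound 1 gives 180 nM.
compound 2 `O=C(Nc1ccc2c(c1)B(O)OC2)c1cccc(C(F)(F)F)c1F`; in this assay compound 2 gives only a limit, > 100000 nM.
compound 3 `O=C(Nc1ccc2c(c1)B(O)OC2)c1cccc(Cl)c1F`; in this assay compound 3 likewise gives only a limit, > 100000 nM.

Within the data shown here, compound 1 holds the only number; the other two values sit at the limit of > 100000 nM in this assay, at which 2 of the 3 values shown sit. The step that the two limits leave unreadable from compound 2 to compound 3 is chloro in place of trifluoromethyl on an aromatic carbon. How the core of compound 1 differs from that of compound 2 is not broken down here. Compound 4 `O=C(Nc1ccc2c(c1)B(O)OC2)c1c(F)cccc1Cl` is not yet measured. It differs from compound 1 by chloro in place of trifluoromethyl on an aromatic carbon, the same kind of change as in compound 3, though here the chloro sits ortho to a large group and meta to a fluoro group, where in compound 3 it sat ortho to a fluoro group and meta to a large group. Compound 1 is expected to give the stronger inhibitor, with the step to compound 4 estimated at a 2.8-fold higher number from compound 1 to compound 4 (0.44 log units; beyond the scatter), resting only on compound 1 at 180 nM and on the unreadable step from compound 2 to compound 3. Compound 4 is therefore estimated at 500 nM, between 120 nM and 3000 nM.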

Compound 4, half-maximal inhibitory concentration: 3100 nM
Compound 4: the middle estimate sits 6.2-fold (0.79 log units) below what was measured; measured number above the stated range.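

On the core of compound 1, chloro in place of trifluoromethyl on an aromatic carbon weakens inhibition in this assay, giving a 17-fold higher number from compound 1 to compound 4 (1.24 log units; beyond the scatter). The same change on the core of compound 2 cannot be read, because neither end of that step gives a number: the limit of > 100000 nM in this assay, at which 2 of the 4 values shown sit. The series therefore gives the size of this change on one core only, and it does not show whether that size or even its direction carries over to the other core.

The compounds shown leave open how a methyl, a methoxy or a nitrile in place of the trifluoromethyl would read on the core of compound 1. They also leave open what hydrogen in place of the fluoro group would do.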